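The source may hold more compounds than are shown below. What is called first, only, known or untested is meant among the compounds shown, and "the series" means these compounds.

For the measured compounds named here, in a physicochemical assay for solubility, at pH 6.8 (a higher number here means a more soluble compound, a lower number a less soluble compound), compound 2 `CN(C)Cc1ccc(-c2cnc(N)c(C(=O)NC[C@@](C)(O)C(F)(F)F)n2)cc1` reads 510000 nM, the only actual number so far. Compound 1 `CCN(CC)C1CCN(Cc2ccc(-c3cnc(N)c(C(=O)N[C@H]4CC[C@H](O)CC4)n3)cc2)CC1` gives > 1000000 nM, which is a limit of the assay and not a number. Compound 3 `CC(O)CNC(=O)c1nc(-c2ccc(CN(C)C)cc2)cnc1N` departs from compound 2 at one place: 1-hydroxyethyl in place of 1-hydroxy-1-(trifluoromethyl)ethyl on a saturated chain carbon bound to an amide-type nitrogen. In words, 1-hydroxyethyl stands in place of 1-hydroxy-1-(trifluoromethyl)ethyl on a saturated chain carbon bound to an amide-type nitrogen, and the rest of the structure is unchanged. Going by the values given here, no measured pair shows this change, so the size of the step remains a judgement. A modest rise in this assay is expected, and the estimated move is a 1.6-fold higher number from compound 2 to compound 3 (0.20 log units; within the scatter). For compound 3 the expected solubility is 800000 nM, with an estimated range of 350000 nM to 1000000 nM.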

Compound 3, solubility: > 1000000 nM
Compound 3 gave a limit, no number; the forecaster's own chance of this, stated with the estimate: 40%; at least 1.2-fold (0.09 log units) between middle value and limit.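

The swap of 1-hydroxy-1-(trifluoromethyl)ethyl for 1-hydroxyethyl on a saturated chain carbon bound to an amide-type nitrogen gives the series its first one-place comparison, and in this assay it reads as an at least 1.9-fold higher number from compound 2 to compound 3 (0.29 log units; that floor lies within the scatter). This shows that the trifluoromethyl group is not needed at this position for a reading at the top of the range, though the floor alone does not separate the two compounds beyond the usual scatter. The size of the step cannot be fixed from this pair, and the ceiling on the read-out now matters at this position: the limit of > 1000000 nM in this assay, at which 2 of the 3 values shown sit.

As far as these compounds go, the true size of the step remains open. So does the outcome at this position with a primary amine, a carboxylic acid or a longer hydroxyalkyl chain in place of 1-hydroxyethyl.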